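The source may report more compounds than this note shows. Statements on the series, on what has been measured and on what is new or still open speak of the compounds shown alone.

Two compounds carry a number in a functional assay on RKE cells for antagonist activity at Vasoactive intestinal polypeptide receptor 1 (Rattus norvegicus), read by HTRF and cAMP accumulation, with stated times of 10 min and 30 min; on this read-out lower numbers stand for stronger inhibition and higher numbers for weaker inhibition. Compound 1, `CC(C)c1cc(C(C)(C)C)cc(-c2ccc(F)cc2)c1CO`, gives 740 nM in this assay. Compound 2, `CC(C)C(=O)Nc1sc2c(c1C#N)CCCC2`, gives 3400 nM in this assay, which is the higher of the two numbers, and the gap between compound 2 and compound 1 lies beyond the scatter. Compound 3, `N#Cc1c(NC(=O)C2CCC2)sc2c1CCCC2`, has not yet been measured. It differs from compound 2 by cyclobutyl in place of isopropyl on a carbonyl carbon, so the amide, the nitrile and the shared core of compound 2 are kept and only the group on the carbonyl carbon changes. Within the data shown here, no pair of measured compounds shows what such a change does in this assay, so the expectation rests on compound 2 alone. This modest change is expected to move the number little, with a step of a 1.1-fold lower number from compound 2 to compound 3 (0.05 log units; within the scatter) that would stay within the scatter. Compound 3 is therefore estimated at 3000 nM, with a range from 1200 nM to 8000 nM.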

Compound 3, half-maximal inhibitory concentration: 1800 nM
Estimate against measurement, compound 3: 1.7-fold (0.22 log units) above; measured number inside the range.
By their numbers in this assay, from the lowest: compound 1; then compounds 3 and 2 (each within the scatter of the next).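

Among these compounds, the step of a 1.9-fold lower number from compound 2 to compound 3 (0.28 log units; within the scatter) gives the first reading of a change at one place: on a carbonyl carbon whose other neighbour is an amide-type nitrogen, cyclobutyl can stand in place of isopropyl without a difference that can be told from the scatter in this assay. So a four-membered ring of carbon, with its one extra heavy atom, is accepted here, and the two groups cannot be ranked on these numbers. Nothing available explains this result or links it to any property of either group.

As far as these compounds go, it remains open whether cyclopentyl, phenyl, a longer chain or an amine on the same carbonyl carbon would hold the number in this region or shift it beyond the scatter. From the compounds shown here alone, the effect of replacing the nitrile or altering the shared core also stays unknown.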